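The source may hold more compounds than are shown below. What is called first, only, known or untested is meant among the compounds shown, and "the series" means these compounds.

Compound 1 `CCOC(=O)c1ccc(-c2nn(Cc3cccc(OC)c3)c3ccccc23)cc1` and compound 2 `CCOC(=O)c1cccc(-c2nn(Cc3ccccc3)c3ccccc23)c1` share the same core and differ in the ester position and in the group on the saturated chain carbon bound to the aromatic nitrogen. In a functional assay on cells (Platelet, Homo sapiens) for inhibition (a higher number here means a weaker inhibitor, a lower number a stronger inhibitor), compound 1 gives > 10000 nM, which is a limit of the assay rather than a number. Compound 2 also sits at a limit in this assay, giving > 10000 nM. For the measured compounds named here, both known values rest at the limit of > 10000 nM in this assay, at which 2 of the 2 values shown sit, so no step between them can be read. Compound 3 `CCCn1nc(-c2ccc(C(=O)OCC)cc2)c2ccccc21` differs from compound 1 by ethyl in place of 3-methoxyphenyl on a saturated chain carbon bound to an aromatic nitrogen. With both known values at the limit, no step beyond the scatter is expected in this assay. Compound 3 is estimated at 30000 nM, within 8000 nM to 100000 nM, most likely again reported only as a limit. The expected step is a step that the limit leaves unreadable from compound 1 to compound 3.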

Compound 3, half-maximal inhibitory concentration: > 10000 nM
Compound 3: a limit, no number; the forecaster's own chance of this, stated with the estimate: 85%; the middle value does not contradict the limit.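

For the compounds shown here, compound 3, like compound 1, sits at a limit, so no step between compound 1 and compound 3 can be read: the limit of > 10000 nM in this assay, at which 3 of the 3 values shown sit. The compounds shown leave open which change to the shared core, if any, would give a measurable value in this assay.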